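Furan-2-yl for 3-Chlorophenyl on a Fused Pyrazole Core

The source may hold more compounds than are shown below. What is called first, only, known or untested is meant among the compounds shown, and "the series" means these compounds.

Measured compounds:
Compound 1, `COc1cccc(-c2nc3c(-c4ccco4)n[nH]c3c(=O)n2NC(=O)c2cccnc2)c1`: 25%
Compound 2, `O=C(Nn1c(-c2cccc([N+](=O)[O-])c2)nc2c(-c3cccc(Cl)c3)n[nH]c2c1=O)c1ccccc1`: "not determined" (no result reported)
Compound 3, `COc1cccc(-c2nc3c(-c4cccc(Cl)c4)n[nH]c3c(=O)n2NC(=O)c2ccccc2)c1`: "not determined" (no result reported)

Three compounds in this series share a fused core and have been examined in a functional assay on SK-OV-3 cells (Homo sapiens) for cytotoxicity, read by sulforhodamine B assay, with a stated time of 2 days, tested at 100 uM; a lower number here means less inhibition, a higher number more inhibition at the concentration tested (going by the name of the read-out). Only compound 1 gives a number there, 25%, which marks modest inhibition at the single concentration tested. For compound 2 the entry in this assay reads "not determined" (no result reported), and for compound 3 it reads "not determined" (no result reported), so compound 3 stands without any number of its own, and the series as a whole rests on a single reading.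

The step of interest leads from compound 3 to compound 4, `COc1cccc(-c2nc3c(-c4ccco4)n[nH]c3c(=O)n2NC(=O)c2ccccc2)c1`, and the structural change is furan-2-yl in place of 3-chlorophenyl on an aromatic carbon. For the measured compounds named here, no pair of measured compounds differs in one place, so no measured step is available to gauge what such a change does in this assay. Lacking any number for compound 3, the step from compound 3 to compound 4 cannot be sized from the data; the only anchor is the reading of compound 1 in this assay, 25%, which places the series at modest inhibition.

On that basis, compound 4 is expected to show inhibition in this assay of about 25%, with a plausible range from 5% to 50%.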

Compound 4, a percentage reported as inhibition, at one concentration (the size of the read-out at that concentration, not a potency): 35.2%
Beside the measured number, compound 4's estimate is 10.2 percentage points below it; low and high end bracket the measured number.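

Compound 3 has no reading in this assay, so the change to furan-2-yl in place of 3-chlorophenyl on the aromatic carbon of the five-membered ring cannot be read, and the result gives no measure of what this position does. For the compounds shown here, what compound 4 adds is a second reading with furan-2-yl in that place, and with it the first measured step: with phenyl in place of pyridin-3-yl on a carbonyl carbon, a number 10.2 percentage points higher from compound 1 to compound 4 (beyond the scatter) shows that the group on the carbonyl carbon can shift the reading while furan-2-yl stays fixed. Nothing at hand accounts for that step.

The compounds shown leave open how furan-2-yl and 3-chlorophenyl compare on the shared core, and a single step cannot show whether phenyl would give the same shift with a different group on the aromatic carbon. They also leave open what an amine or a carboxylic acid in place of furan-2-yl, or a longer chain in place of phenyl on the carbonyl carbon, would give in this assay.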